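A few compounds are considered here, and "the series" means these few. Any claim that something is new, unique, unknown or untested is made for them only; others in the source may bear on it.

Working notes on a small set of cathepsin S inhibitors. The common core carries a nitrile and a side chain ending in a morpholine amide. Compound 1 `N#C[C@@]1(NC(=O)[C@@H](CC(=O)N2CCOCC2)CC2CCC(c3ccccc3)CC2)CCN(C2CCCCC2)C1` and compound 2 `N#C[C@@]1(NC(=O)[C@@H](CC(=O)N2CCOCC2)CC2CCCCC2)CCN(C2CCCC2)C1` both carry the nitrile on a five-membered ring with one nitrogen, with a cyclohexyl or a cyclopentyl on that ring nitrogen. Compound 3 `N#C[C@H](CCc1ccccc1)NC(=O)[C@@H](CC(=O)N1CCOCC1)CC1CCCCC1` instead carries the nitrile on an open chain.

In an assay on isolated protein for inhibition of cathepsin S (Homo sapiens) (a higher number here means weaker binding, a lower number tighter binding), compound 3 gives 25 nM. In this assay compound 2 gives "not determined" (no result reported), so no result was reported for it. In this assay compound 1 likewise gives "not determined" (no result reported), so nothing in the set places the ring-bearing compounds against compound 3.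

Compound 4 `CC(C)N1CC[C@@](C#N)(NC(=O)[C@@H](CC(=O)N2CCOCC2)CC2CCCCC2)C1` differs from compound 2 in one place: isopropyl in place of cyclopentyl on an amine nitrogen in a ring. For the measured compounds named here, no measured step in this assay covers a change of this kind, nor any step at all, so no size or direction can be read from the data; a change of a small alkyl on a ring amine nitrogen is taken here as likely to stay within the usual scatter of this assay.

Going by the values given here, with compound 3 at 25 nM as the only number in the set, compound 4 is expected to fall near 30 nM in this assay, with a range of 5 nM to 200 nM.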

Compound 4, dissociation constant: 60.6 nM
The estimate for compound 4 lay 2.0-fold (0.31 log units) below the measured number; measured number inside the range.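

Compound 2 has no number to set against compound 4 in this assay, so no step can be read between compound 2 and compound 4. The compounds shown leave open how isopropyl, cyclopentyl or cyclohexyl on the amine nitrogen in the ring bears on binding in this assay. No outside evidence bears on this result.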